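The compounds below may be only part of what the source reports. "The series", "measured", "known", "first", "only" and "open" are said of these compounds alone.

Values measured so far in an ADME assay on HEK293 cells (Homo sapiens) for cytotoxicity, read by MTT assay, with a stated time of 48 h; a higher number here means a weaker inhibitor, a lower number a stronger inhibitor:

- Compound 1 `O=C1/C(=C\c2ccccc2)S/C(=N/c2ccccc2)N1Cc1ccncc1`: 64700 nM
- Compound 2 `Cc1ccc(/C=C2/S/C(=N/c3ccccc3)N(Cc3ccncc3)C2=O)cc1`: 49500 nM
- Compound 3 `COc1ccc(OC)c(/C=C2/S/C(=N/c3ccccc3)N(Cc3ccncc3)C2=O)c1`: 80100 nM

Compound 3 sits within the usual scatter of both other compounds. Compound 4 `Cc1ccc(/C=C2/S/C(=N/c3ccccc3)N(Cc3ccncc3)C2=O)s1` has not yet been measured. Its structure differs from that of compound 3 as follows: 5-methylthiophen-2-yl in place of 2,5-dimethoxyphenyl on a double-bonded chain carbon bound to a double-bonded ring carbon. That is, 5-methylthiophen-2-yl stands in place of 2,5-dimethoxyphenyl on a double-bonded chain carbon bound to a double-bonded ring carbon.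

Two measured changes at this same place bear on it: a 1.2-fold higher number from compound 1 to compound 3 (0.09 log units; within the scatter) and a 1.6-fold higher number from compound 2 to compound 3 (0.21 log units; within the scatter). For the measured compounds named here, neither exceeds the scatter, although no measured compound carries a five-membered aromatic ring here, so the comparison is indirect.

The expected change is a 1.3-fold lower number from compound 3 to compound 4 (0.13 log units; within the scatter), which would be no real step beyond the scatter. The estimate for compound 4 is 60000 nM, with an expected range of 32000 nM to 110000 nM.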

Compound 4, half-maximal inhibitory concentration: 146000 nM
The estimate for compound 4 lay 2.4-fold (0.39 log units) below the measured number, and the stated range ends below it.
By their numbers in this assay, from the lowest: compounds 2, 1, 3 and 4 (each within the scatter of the next, the first and the last beyond it).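

In this assay, swapping phenyl for 5-methylthiophen-2-yl on the double-bonded chain carbon gives a 2.3-fold higher number from compound 1 to compound 4 (0.35 log units; beyond the scatter) and swapping 4-methylphenyl for it gives a 2.9-fold higher number from compound 2 to compound 4 (0.47 log units; beyond the scatter), so a change at this place can move the number beyond the scatter. The pattern is incomplete: the swap from 2,5-dimethoxyphenyl gives a 1.8-fold higher number from compound 3 to compound 4 (0.26 log units; within the scatter) and so does not separate compound 3 from compound 4. No measurement here accounts for the shift. The compounds shown leave open whether the sulfur ring or its methyl goes with the higher number. They also leave open how a furan-2-yl ring, or a phenyl bearing an amine, would read.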